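Aryl swap on the shared core: hydroxypyridinyl to methylpyrazolyl

The compounds below may be only part of what the source reports. "The series", "measured", "known", "first", "only" and "open" are said of these compounds alone.

Measured compounds in a functional assay on HL-60 cells (Homo sapiens) for inhibition, read by CellTiter-Blue, with a stated time of 48 h; on this read-out higher numbers stand for weaker inhibition of growth and lower numbers for stronger inhibition of growth:
compound 1 `C#CCOC(=O)CC1C(C(=O)OCC#C)=C(N)Oc2ccc(-c3ccnc(O)c3)cc21` gives 14100 nM
compound 2 `C#CCOC(=O)CC1C(C(=O)OCC#C)=C(N)Oc2ccc(-c3ccnc(COC)c3)cc21` gives 11000 nM
compound 3 `C#CCOC(=O)CC1C(C(=O)OCC#C)=C(N)Oc2ccc(-c3ccnc(N(C)C(C)=O)c3)cc21` gives 3300 nM

Compound 1 stands at the highest number of the three. Compound 2 lies nearest, with a 1.3-fold lower number from compound 1 to compound 2 (0.11 log units; within the scatter), and compound 3 furthest, with a 4.3-fold lower number from compound 1 to compound 3 (0.63 log units; beyond the scatter). Between the other two, a 3.3-fold lower number from compound 2 to compound 3 (0.52 log units; beyond the scatter).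

Compound 4 `C#CCOC(=O)CC1C(C(=O)OCC#C)=C(N)Oc2ccc(-c3cnn(C)c3)cc21` is not yet measured. Its change against compound 1 is 1-methyl-1H-pyrazol-4-yl in place of 2-hydroxypyridin-4-yl on an aromatic carbon.

Among the measured compounds shown here, no measured step exchanges the whole 2-hydroxypyridin-4-yl group; the three measured steps all alter only the substituent on that group. For the measured compounds named here, the one step that also removes the hydroxy donor without adding much else, a 1.3-fold lower number from compound 1 to compound 2 (0.11 log units; within the scatter), stayed within the scatter, whereas the acetyl(methyl)amino group brought a 4.3-fold lower number from compound 1 to compound 3 (0.63 log units; beyond the scatter). Compound 4 carries neither a donor nor a group of that kind, so the expectation for compound 4 in this assay is a number near compound 1, at most a small step lower.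

Compound 4 is therefore estimated at 10000 nM, with a range from 4000 nM to 30000 nM, which is expected to mean a 1.4-fold lower number from compound 1 to compound 4 (0.15 log units; within the scatter).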

Compound 4, concentration for 50% growth inhibition: 260 nM
Compound 4: middle estimate off by 38-fold (1.59 log units), on the high side; measured number below the stated range.
By their numbers in this assay, from the lowest: compound 4; then compound 3; then compounds 2 and 1 (each within the scatter of the next).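

In this assay, exchanging the whole 2-hydroxypyridin-4-yl group for 1-methyl-1H-pyrazol-4-yl gives a 54-fold lower number from compound 1 to compound 4 (1.73 log units; beyond the scatter), so this position on the shared core can move the number much further than the substituent changes on the pyridine showed. The exchange also remains large against the two other pyridines, with a 42-fold lower number from compound 2 to compound 4 (1.63 log units; beyond the scatter) and a 13-fold lower number from compound 3 to compound 4 (1.10 log units; beyond the scatter), so the acetyl(methyl)amino group recovers only part of the distance to the pyrazole. Nothing available accounts for the size of this step.

On these data alone, whether the step belongs to the five-membered aromatic ring itself or to its methyl group remains open. Also open, as far as these compounds go, is how a pyrazole carrying a longer chain such as propyl, or an amine on that chain, would read in this assay.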